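Cytotoxicity notes on the shared core: compound 2 to compound 4

A few compounds are considered here, and "the series" means these few. Any claim that something is new, unique, unknown or untested is made for them only; others in the source may bear on it.

Compound 1 `CC1CN(C(=O)Nc2cc(F)c(F)c(F)c2)Cc2c(N3CC(C#N)CC3=O)cnn21`, compound 2 `O=C1CC(c2ccc(F)cn2)CN1c1cnn2c1CN(C(=O)Nc1cc(F)c(F)c(F)c1)C(C1CC1)C2` and compound 3 `C[C@H]1Cn2ncc(N3CC(c4ccccc4)CC3=O)c2CN1C(=O)NCc1cc(F)c(F)c(F)c1` are built on one shared core. In a toxicity assay on HepG2 2.2.15 cells (Homo sapiens) for cytotoxicity, read by CellTiter-Glo (a lower number here means that less compound is tolerated, a higher number that more compound is tolerated), compound 1 gives 115000 nM and compound 2 gives 38500 nM. For compound 3 the reading of > 2000 nM in this assay is a limit of the assay, not a number. Among the two numbers compound 2 stands lowest, with compound 1 above it by a gap that lies beyond the usual scatter.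

Compound 4 `O=C1CC(c2cnc(C(F)(F)F)s2)CN1c1cnn2c1CN(C(=O)Nc1cc(F)c(F)c(F)c1)C(C1CC1)C2` is not yet measured in this assay. It differs from compound 2 in a single place: 2-(trifluoromethyl)-1,3-thiazol-5-yl in place of 5-fluoropyridin-2-yl on a saturated ring carbon. Among the compounds with values here, no measured pair in the set isolates this change, so its size is not known from the data.

A step of modest size, if any, is expected here, with no clear direction beyond the scatter. Compound 4 is expected to give 30000 nM in this assay, with a range from 12000 nM to 75000 nM. The expected step of a 1.3-fold lower number from compound 2 to compound 4 (0.11 log units; within the scatter) is therefore estimated to be small.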

Compound 4, half-maximal cytotoxic concentration: 38500 nM
Compound 4: the middle estimate sits 1.3-fold (0.11 log units) below what was measured; the range from low to high includes it.
By their numbers in this assay, from the lowest: compounds 2 and 4 (each within the scatter of the next); then compound 1.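

In this assay, within the data shown here, 2-(trifluoromethyl)-1,3-thiazol-5-yl in place of 5-fluoropyridin-2-yl on a saturated ring carbon gives no change at the digits printed from compound 2 to compound 4 (within the scatter), the first step that isolates a change at this position. The earlier compounds shown here gave no such pair, and this one shows that the position can take a five-membered aromatic ring in place of a six-membered one with no step beyond the scatter in this read-out. No measurement at hand bears on why the two compounds read alike.

Both groups at this carbon are fluorinated aromatic rings, so the compounds shown leave open how a carboxylic acid or a primary amine there would read. Also open, as far as these compounds go, is whether this step would hold on another member of the series carrying the same pair of groups.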